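The compounds below may be only part of what the source reports. "The series", "measured", "known", "first", "only" and "open" are said of these compounds alone.

Compound 2 `Cc1nc2c3ccccc3ccc2c2nc3c(ccc4ccccc43)c(-c3nccnc3N)c12` and compound 3 `Cc1nc2c3ccccc3ccc2c2nc3c(ccc4ccccc43)c(-c3cccnc3)c12` share their core with compound 1 `Cc1nc2c3ccccc3ccc2c2nc3c(ccc4ccccc43)c(-c3ccccc3Cl)c12`. In a functional assay, read by spectrophotometry, with a stated time of 15 min (on this read-out lower numbers stand for stronger inhibition and higher numbers for weaker inhibition), compound 2 gives 47.8 ug/mL, and compound 1 gives 74.6 ug/mL; the two numbers lie within the scatter of each other, as the step of a 1.6-fold lower number from compound 1 to compound 2 (0.19 log units; within the scatter) shows. Compound 3 differs from compound 2 by pyridin-3-yl in place of 3-aminopyrazin-2-yl on an aromatic carbon. Going by the values given here, the only measured step, which also exchanged the group at this place, stayed within the scatter, so no change beyond the scatter is expected here, in either direction. Compound 3 is therefore expected near 55 ug/mL, between 28 ug/mL and 110 ug/mL. That amounts to an expected step of a 1.2-fold higher number from compound 2 to compound 3 (0.06 log units; within the scatter).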

Compound 3, half-maximal inhibitory concentration: 63.6 ug/mL
The estimate for compound 3 lay 1.2-fold (0.06 log units) below the measured number; measured number inside the range.
By their numbers in this assay, from the lowest: compounds 2, 3 and 1 (each within the scatter of the next).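

In this assay, both new steps, a 1.3-fold higher number from compound 2 to compound 3 (0.12 log units; within the scatter) and a 1.2-fold lower number from compound 1 to compound 3 (0.07 log units; within the scatter), stay within the scatter, so three different aromatic rings at this place cannot be told apart. Even the exchange of 3-aminopyrazin-2-yl, with its hydrogen-bond donor, for pyridin-3-yl, with none, gives no readable change. Nothing measured here offers an explanation for this. Still open, going by these compounds, is whether a group of another kind at this place, such as a carboxylic acid, a simple amine or a longer alkyl chain, would give a step beyond the scatter.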